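The compounds below may be only part of what the source reports. "The series", "measured", "known", "first", "only" and "open" are said of these compounds alone.

Compound 1 `NCCNc1cc(N2CCN(C(=O)CCc3ccccc3)CC2)nc2ccccc12` in an ADME assay on HEp-2 cells (Homo sapiens) for cytotoxicity, read by CCK-8 assay, with a stated time of 6 days (a higher number here means that more compound is tolerated, a lower number that less compound is tolerated), gives > 100000 nM.
Compound 2 `NCCNc1cc(N2CCN(C(=O)C3(c4ccccc4)CCCC3)CC2)nc2ccccc12` gives > 100000 nM.

The value of compound 1 is a limit, not a number. The value of compound 2 is likewise a limit, so compound 2 stands only at the edge of what can be read. Among the measured compounds shown here, the step that the two limits leave unreadable from compound 1 to compound 2 is therefore unreadable; the sole evidence is the limit of > 100000 nM in this assay, at which 2 of the 2 values shown sit. Compound 3 `NCCNc1cc(N2CCN(C(=O)C3CCCCC3)CC2)nc2ccccc12` differs from compound 2 by cyclohexyl in place of 1-phenylcyclopentyl on a carbonyl carbon. For the measured compounds named here, no measured step bears on this change, and no direction can be read from two limits. The step of a number no higher from compound 2 to compound 3 (the limit leaves the size open) is expected to stay near the limit. Compound 3 is estimated at 100000 nM, within 40000 nM to 250000 nM.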

Compound 3, half-maximal cytotoxic concentration: > 100000 nM
Compound 3 gave a limit, no number; the forecaster's own chance of this, stated with the estimate: 80%; the middle value sits exactly at the limit.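

Among the compounds shown here, compound 3 also gives only a limit in this assay, so no step among compound 1, compound 2 and compound 3 can be read: the limit of > 100000 nM in this assay, at which 3 of the 3 values shown sit. The compounds shown leave open where any of their true cytotoxic concentrations lies, and whether the group on the carbonyl carbon changes it at all.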